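A few compounds are considered here, and "the series" means these few. Any claim that something is new, unique, unknown or untested is made for them only; others in the source may bear on it.

In a functional assay on HGC-27 cells (Homo sapiens) for antiproliferative activity, read by MTT assay, with stated times of 72 h and 4 h (a higher number here means a weaker inhibitor, a lower number a stronger inhibitor), compound 1 (`COc1ncc(-c2cc3c(N4CC(C)OC(C)C4)ncnc3s2)cc1NS(=O)(=O)c1ccc(F)cc1F`) gives 860 nM and compound 2 (`COc1ncc(-c2cc3c(N4CC5CCCC5C4)ncnc3s2)cc1NS(=O)(=O)c1ccc(F)cc1F`) gives 1900 nM, the higher of the two numbers. Compound 3 (`COc1ncc(-c2cc3c(N4CCN(C)C(=O)C4)ncnc3s2)cc1NS(=O)(=O)c1ccc(F)cc1F`) is not yet measured and differs from compound 2 on an aromatic carbon: a group of 8 heavy atoms (5 carbon, 2 nitrogen, 1 oxygen; one six-membered non-aromatic ring with 2 hetero atoms) in place of a group of 8 heavy atoms (7 carbon, 1 nitrogen; one five-membered non-aromatic ring of carbon only, one five-membered non-aromatic ring with 1 hetero atom), on an aromatic carbon. Among the compounds with values here, only one measured step bears on this change, a 2.2-fold higher number from compound 1 to compound 2 (0.34 log units; beyond the scatter), which was modest and also left a six-membered non-aromatic ring with 2 hetero atoms for the fused five-membered rings. The reverse change is therefore expected to give a small move to a lower number in this assay, with a 1.7-fold lower number from compound 2 to compound 3 (0.24 log units; within the scatter) as the estimated step. For compound 3 the estimated value is 1100 nM, with an expected range of 350 nM to 3500 nM.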

Compound 3, half-maximal inhibitory concentration: 920 nM
Beside the measured number, compound 3's estimate is 1.2-fold (0.08 log units) above it; the measured number falls inside the stated range.
By their numbers in this assay, from the lowest: compounds 1 and 3 (each within the scatter of the next); then compound 2.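

In this assay, the 4-methyl-3-oxopiperazin-1-yl group gives a 2.1-fold lower number from compound 2 to compound 3 (0.31 log units; beyond the scatter), so a second six-membered non-aromatic ring now stands apart from the fused five-membered rings of compound 2, though only modestly. In place of 2,6-dimethylmorpholin-4-yl, the same group gives a 1.1-fold higher number from compound 1 to compound 3 (0.03 log units; within the scatter), so the assay does not separate these two six-membered rings. No measurement given here offers a cause for either step. Still open, from the compounds shown here alone, is how an unsubstituted morpholine, a piperazine with a free ring nitrogen, or an open-chain dimethylamino group would read at this place.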